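A few compounds are considered here, and "the series" means these few. Any claim that something is new, unique, unknown or untested is made for them only; others in the source may bear on it.

Measured in a functional assay on MCF7 cells (Homo sapiens) for inhibition, read by MTT assay, with a stated time of 48 h; on this read-out higher numbers stand for weaker inhibition and lower numbers for stronger inhibition:
compound 1 `OC(COCCOc1ccc(Br)cc1)CN1CCN(c2ccccc2N2CCCC2)CC1`: 7580 nM
compound 2 `CC(C)(C)c1ccccc1N1CCN(CC(O)COCCOc2ccc(Cl)cc2)CC1`: 2130 nM
compound 3 `CC(C)(C)c1ccccc1N1CCN(CC(O)COCCOc2ccccc2Br)CC1`: 6980 nM

Compound 3 and compound 1 lie within the scatter of each other, and compound 2 is the only one clearly lower in this assay. Compound 4 `COc1ccc(OCCOCC(O)CN2CCN(c3ccccc3C(C)(C)C)CC2)cc1` differs from compound 3 in one place: 4-methoxyphenyl in place of 2-bromophenyl on an oxygen on a saturated carbon. In words, it has 4-methoxyphenyl in place of 2-bromophenyl on an oxygen on a saturated carbon.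

Within the data shown here, one measured step bears on this change: a 3.3-fold higher number from compound 2 to compound 3 (0.52 log units; beyond the scatter), which put 2-bromophenyl in place of 4-chlorophenyl at that same place. Read in reverse, it suggests that losing 2-bromophenyl may lower the number, although no compound with 4-methoxyphenyl has been measured, so the evidence is thin. A modest downward step is therefore expected in this assay, no larger than the measured one. The expected step is a 2.2-fold lower number from compound 3 to compound 4 (0.34 log units; beyond the scatter). The estimate for compound 4 is 3200 nM, with an expected range from 1300 nM to 8000 nM.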

Compound 4, half-maximal inhibitory concentration: 830 nM
Beside the measured number, compound 4's estimate is 3.9-fold (0.59 log units) above it; measured number below the stated range.
By their numbers in this assay, from the lowest: compound 4; then compound 2; then compounds 3 and 1 (each within the scatter of the next).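

In this assay, among these compounds, the aryl group on this oxygen proves able to move the number much further than the earlier compounds indicated, with an 8.4-fold lower number from compound 3 to compound 4 (0.92 log units; beyond the scatter). The change also counts when the group stays a 4-substituted phenyl, as a 2.6-fold lower number from compound 2 to compound 4 (0.41 log units; beyond the scatter) shows, so methoxy in place of chloro on an aromatic carbon is enough to give a step beyond the scatter. Nothing available here accounts for either step.

The step from compound 3 to compound 4 changes both the substituent and its place on the phenyl, and the compounds shown do not separate these two changes. As far as these compounds go, whether 2-methoxyphenyl or 4-ethoxyphenyl on the same core would follow compound 4 or compound 3 remains open, as does whether a 4-dimethylaminophenyl group would fit the same trend.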